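The compounds below may be only part of what the source reports. "The series", "measured", "known", "first", "only" and "open" are said of these compounds alone.

Among the compounds with values here, compound 3 `CN(C)CCn1cnnc1-c1cc(Oc2ccc(NC(=O)N/N=C/c3ccc(O)cc3)cc2F)ccn1` gives 3560 nM in a functional assay on A549 cells (Homo sapiens) for cytotoxicity, read by MTT assay, with a stated time of 72 h (on this read-out higher numbers stand for weaker inhibition and lower numbers for stronger inhibition), the highest of the three numbers measured so far. Compound 1 `CN(C)CCn1cnnc1-c1cc(Oc2ccc(NC(=O)N/N=C/c3ccc(O)c(Br)c3)cc2F)ccn1` gives 1370 nM and compound 2 `CN(C)CCn1cnnc1-c1cc(Oc2ccc(NC(=O)N/N=C/c3ccc(F)cc3)cc2F)ccn1` gives 1790 nM in this assay; the step of a 2.6-fold higher number from compound 1 to compound 3 (0.41 log units; beyond the scatter) is modest but beyond the scatter, whereas a 2.0-fold higher number from compound 2 to compound 3 (0.30 log units; within the scatter) and a 1.3-fold higher number from compound 1 to compound 2 (0.12 log units; within the scatter) stay within it. Compound 4 `CN(C)CCn1cnnc1-c1cc(Oc2ccc(NC(=O)N/N=C/c3ccc(O)cc3O)cc2F)ccn1` differs from compound 3 by hydroxy in place of hydrogen on an aromatic carbon. Within the data shown here, the closest precedent is a 2.6-fold higher number from compound 1 to compound 3 (0.41 log units; beyond the scatter), in which a second group on the 4-hydroxyphenyl accompanied a lower number. Among the measured compounds shown here, no measured step introduces a hydroxy at this place, so only a small shift, if any, is expected. Compound 4 is therefore expected to give 2600 nM, with a range from 1000 nM to 6500 nM. The expected step of a 1.4-fold lower number from compound 3 to compound 4 (0.14 log units; within the scatter) is estimated to stay within the scatter.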

Compound 4, half-maximal inhibitory concentration: 12700 nM
The estimate for compound 4 lay 4.9-fold (0.69 log units) below the measured number; measured number outside the range, above it.
By their numbers in this assay, from the lowest: compounds 1, 2 and 3 (each within the scatter of the next, the first and the last beyond it); then compound 4.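

In this assay, hydroxy in place of hydrogen on this aromatic carbon, ortho to a large group and meta to a hydroxy group, gives a step beyond the scatter (a 3.6-fold higher number from compound 3 to compound 4 (0.55 log units; beyond the scatter)), so a second group on the 4-hydroxyphenyl does not always accompany a lower number, as the bromo of compound 1 did. The 2,4-dihydroxyphenyl also stands apart from the other two aryl groups (a 7.1-fold higher number from compound 2 to compound 4 (0.85 log units; beyond the scatter); a 9.3-fold higher number from compound 1 to compound 4 (0.97 log units; beyond the scatter)). No measurement shown accounts for this rise.

On these data alone, whether a methoxy or an amine on this carbon would give a similar rise remains open. So does the effect of a fluoro or bromo here.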